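A few compounds are considered here, and "the series" means these few. Any claim that something is new, unique, unknown or untested is made for them only; others in the source may bear on it.

Measured compounds:
compound 1 `COc1cc[nH]c1/C=C1\C(=O)Nc2ccc([N+](=O)[O-])c(N[C@H]3CC[C@H](N)C3)c21` — 61 nM
compound 2 `COc1cc[nH]c1/C=C1\C(=O)Nc2ccc([N+](=O)[O-])c(N3CCC(N)CC3)c21` — < 10 nM

In a functional assay on MDA-MB-435 cells (Homo sapiens) for antiproliferative activity, read by MTT assay, with a stated time of 5 days (on this read-out higher numbers stand for weaker inhibition and lower numbers for stronger inhibition), compound 1 gives 61 nM. Compound 2 sits at a limit of the assay, < 10 nM, so its true number is not known (the limit of < 10 nM in this assay, at which 1 of the 2 values shown sits). Within the data shown here, the only measured step, an at least 6.1-fold lower number from compound 1 to compound 2 (0.78 log units; beyond the scatter), concerns a different exchange and does not bear directly on the change at hand. Compound 3 `COc1cc[nH]c1/C=C1\C(=O)Nc2ccc([N+](=O)[O-])c(N3CCCC(CO)C3)c21` differs from compound 2 by 3-(hydroxymethyl)piperidin-1-yl in place of 4-aminopiperidin-1-yl on an aromatic carbon. Among the measured compounds shown here, no measured step covers this change, and the starting point itself is only a limit. Compound 3 is expected to come out weaker, an at least 4.0-fold higher number from compound 2 to compound 3 (0.60 log units; beyond the scatter). The estimate for compound 3 is 40 nM, within 8 nM to 200 nM.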

Compound 3, half-maximal inhibitory concentration: 441 nM
The estimate for compound 3 lay 11-fold (1.04 log units) below the measured number; the whole stated range lies below it.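

In this assay, 3-(hydroxymethyl)piperidin-1-yl on this aromatic carbon, ortho to a nitro group, gives an at least 44-fold higher number from compound 2 to compound 3 (1.64 log units; beyond the scatter), so this position does not accept every piperidine equally. Attachment through the piperidine nitrogen does not by itself keep the number low, as (3-aminocyclopentyl)amino also does better, with a 7.2-fold higher number from compound 1 to compound 3 (0.86 log units; beyond the scatter). Compound 2 is a limit, so the first step has no upper end: the limit of < 10 nM in this assay, at which 1 of the 3 values shown sits.

From the compounds shown here alone, the two piperidines differ in both the substituent and its ring position, so the contribution of each stays open. 3-Aminopiperidin-1-yl or 4-(hydroxymethyl)piperidin-1-yl would separate them.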